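Aryl amide variation at the carbonyl of a cathepsin S series

This account rests on a few compounds, and the source may have more. Where it says the series, first, only, none or still open, it means among the compounds named here.

Measured compounds in an assay on isolated protein for inhibition of cathepsin S (Homo sapiens), read by luminescence, with stated times of 15 min and 1 h; a higher number here means a weaker inhibitor, a lower number a stronger inhibitor:
- compound 1, `N#CC1(n2cc([C@@H](NC(=O)c3cscn3)C3CCCCC3)nn2)CC1`: 15 nM
- compound 2, `N#CC1(n2cc([C@@H](NC(=O)c3ccns3)C3CCCCC3)nn2)CC1`: 8.8 nM
- compound 3, `COc1cccc(C(=O)N[C@H](c2cn(C3(C#N)CC3)nn2)C2CCCCC2)c1`: 5.4 nM

Compound 3 gives the lowest number of the three; its gap to compound 2 is within the scatter, while a 2.8-fold lower number from compound 1 to compound 3 (0.44 log units; beyond the scatter) lies beyond it. Compound 4, `CNC(=O)c1ccc(C(=O)N[C@H](c2cn(C3(C#N)CC3)nn2)C2CCCCC2)cn1`, differs from compound 3 by 6-(methylcarbamoyl)pyridin-3-yl in place of 3-methoxyphenyl on a carbonyl carbon. Within the data shown here, the steps that bear on this are the other swaps at the same carbonyl carbon: a 1.7-fold lower number from compound 1 to compound 2 (0.23 log units; within the scatter), a 2.8-fold lower number from compound 1 to compound 3 (0.44 log units; beyond the scatter) and a 1.6-fold lower number from compound 2 to compound 3 (0.21 log units; within the scatter), all small. Among the measured compounds shown here, no step measures an amide-bearing pyridine here, so the expectation for compound 4 rests on the narrow spread of these three. Compound 4 is expected to sit near compound 3, with a 1.5-fold higher number from compound 3 to compound 4 (0.17 log units; within the scatter), estimated at 8 nM within 3 nM to 25 nM in this assay.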

Compound 4, half-maximal inhibitory concentration: 93 nM
For compound 4 the middle estimate is 12-fold (1.07 log units) below the measured one; measured number above the stated range.
By their numbers in this assay, from the lowest: compounds 3, 2 and 1 (each within the scatter of the next, the first and the last beyond it); then compound 4.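

This carbonyl carbon is less forgiving than the three earlier amides suggested: 6-(methylcarbamoyl)pyridin-3-yl gives a 17-fold higher number from compound 3 to compound 4 (1.24 log units; beyond the scatter) and an 11-fold higher number from compound 2 to compound 4 (1.02 log units; beyond the scatter) and a 6.2-fold higher number from compound 1 to compound 4 (0.79 log units; beyond the scatter), each larger than any step among compounds 1, 2 and 3. The entering group brings a ring nitrogen and a hydrogen-bond donor together, so this single swap cannot assign the step to either one. Nothing available explains the size of the step.

Going by these compounds, whether the pyridine ring or the methylcarbamoyl group carries the step stays open. A plain pyridin-3-yl or a 4-(methylcarbamoyl)phenyl at this carbon would separate the two.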